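This account rests on a few compounds, and the source may have more. Where it says the series, first, only, none or still open, it means among the compounds named here.

In an in vivo ADME assay on the whole organism (strain 129/SvEvBrd x C57BL/6) for pharmacokinetics, with Mus musculus as the target, at a dose of 1 mg/kg by the intravenous route (a higher number here means faster removal of the compound, a lower number slower removal), compound 1 (`CC(=O)c1nc([C@@H](O)[C@H](O)[C@H](O)CO)cn1C`) gives 5.7 mL/min/kg and compound 2 (`Cc1nc(-c2nc([C@@H](O)[C@H](O)[C@H](O)CO)c[nH]2)cs1`) gives 19.4 mL/min/kg as its result. Compound 2 therefore holds the higher of the two numbers, and the gap is larger than repeat measurements would normally produce. These two compounds differ in more than one place, so the gap cannot be traced to any single group.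

Compound 3 (`Cn1cnc(-c2nc([C@@H](O)[C@H](O)[C@H](O)CO)c[nH]2)c1`) is a closer relative of compound 2. It carries 1-methyl-1H-imidazol-4-yl in place of 2-methyl-1,3-thiazol-4-yl on an aromatic carbon. Among the compounds with values here, the swap keeps a five-membered aromatic ring at that spot, but no measured pair tests this change directly, so any forecast is loose. With so little data, the expectation leans toward the middle of the two known results, compound 1 at 5.7 mL/min/kg and compound 2 at 19.4 mL/min/kg in the same test. The expected change a 1.8-fold lower number from compound 2 to compound 3 (0.25 log units; within the scatter) is a modest fall that may stay within the usual scatter. In this assay the estimate for compound 3 is 11 mL/min/kg with an expected range from 5 mL/min/kg to 24 mL/min/kg overall.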

Compound 3, clearance: 9.1 mL/min/kg
Beside the measured number, compound 3's estimate is 1.2-fold (0.08 log units) above it; measured number inside the range.
By their numbers in this assay, from the lowest: compounds 1 and 3 (each within the scatter of the next); then compound 2.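

In this assay, within the data shown here, putting 1-methyl-1H-imidazol-4-yl in place of 2-methyl-1,3-thiazol-4-yl gives a 2.1-fold lower number from compound 2 to compound 3 (0.33 log units; beyond the scatter), the first comparison here in which only one group changes. The step is modest, but it shows that this aromatic carbon, between two ring nitrogen atoms, is sensitive to which ring it carries, even though both groups are five-membered aromatic rings with the same count of heavy atoms, hydrogen-bond donors and hydrogen-bond acceptors. Nothing available explains why removal of the compound changes with this swap.

The swap changes two things at once, replacing the ring sulfur with nitrogen and moving the methyl group from a ring carbon to a ring nitrogen, so this single pair cannot show which of the two goes with the lower number. It also leaves open how this position would respond to a group of a different kind, such as a six-membered phenyl ring, an amine or a carboxylic acid.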